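The compounds below may be only part of what the source reports. "The series", "measured", "known", "first", "only" and "open" are said of these compounds alone.

Three compounds have been measured in a functional assay on a cell-free system (plasma, Oryctolagus cuniculus) for inhibition of platelet-activating factor acetylhydrolase (Homo sapiens), tested at 100 nM; a lower number here means less inhibition, a higher number more inhibition at the concentration tested (going by the name of the read-out):

Compound 1 `CCCCCCCCN(C)C(=O)Cn1cc(Cc2cnc(=O)n(CC(=O)NC)c2)c(=O)nc1SCc1ccc(F)cc1` gives 42%.
Compound 2 `CCCCCCCCN(C)C(=O)Cn1cc(Cc2cnc(=O)n(CC(=O)NCCO)c2)c(=O)nc1SCc1ccc(F)cc1` gives 40%.
Compound 3 `CCCCCCCCCCCCN(C)C(=O)Cn1cc(Cc2cnc(=O)n(CC(=O)NC)c2)c(=O)nc1SCc1ccc(F)cc1` gives 28%.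

Compound 2 differs from compound 1 only in one place, (hydroxymethyl in place of hydrogen on a saturated chain carbon bound to an amide-type nitrogen), and the step is a number 2 percentage points lower from compound 1 to compound 2 (within the scatter). Compound 3 carries the core of compound 1 lengthened by butyl in place of hydrogen on a saturated chain carbon, eight bonds along the chain from an amide-type nitrogen, and here the step is a number 14 percentage points lower from compound 1 to compound 3 (beyond the scatter), leaving compound 3 with the lowest of the three numbers. Compound 4 `CCCCCCCCCCCCN(C)C(=O)Cn1cc(Cc2cnc(=O)n(CC(=O)NCCO)c2)c(=O)nc1SCc1ccc(F)cc1` is still to be measured in this assay. It is built from compound 3 by hydroxymethyl in place of hydrogen on a saturated chain carbon bound to an amide-type nitrogen, the same change that turns compound 1 into compound 2, at the same place. Since that earlier change gave a number 2 percentage points lower from compound 1 to compound 2 (within the scatter), the expected step is a number 2 percentage points lower from compound 3 to compound 4 (within the scatter). Compound 4 is therefore estimated at 26%, expected to lie between 14% and 38%.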

Compound 4, a percentage reported as inhibition, at one concentration (the size of the read-out at that concentration, not a potency): 37%
Compound 4: the middle estimate sits 11 percentage points below what was measured; measured number inside the range.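

In this assay, hydroxymethyl in place of hydrogen on a saturated chain carbon bound to an amide-type nitrogen gives a number 9 percentage points higher from compound 3 to compound 4 (within the scatter), and this step cannot be told apart from its earlier counterpart: the same change on two cores in this assay, a number 2 percentage points lower (within the scatter) from compound 1 to compound 2 and a number 9 percentage points higher (within the scatter) from compound 3 to compound 4, 11 percentage points apart, within the scatter of two such steps. The butyl change, read on the other pair, gives a number 3 percentage points lower from compound 2 to compound 4 (within the scatter), and it too cannot be told apart from its earlier step: the same change on two cores in this assay, a number 14 percentage points lower (beyond the scatter) from compound 1 to compound 3 and a number 3 percentage points lower (within the scatter) from compound 2 to compound 4, 11 percentage points apart, within the scatter of two such steps. So each change can be said to carry across these two cores, but with only one repeat of each, this does not show that the steps are truly equal or that they would hold on other cores.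

The compounds shown leave open how an amine or a carboxylic acid would fare in place of the hydroxymethyl. They also leave open what a still longer chain would do.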